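Swapping One Halogenated Phenyl Ring for Another

This account rests on a few compounds, and the source may have more. Where it says the series, first, only, none or still open, it means among the compounds named here.

Of the compounds shown here, three have so far been measured in an ADME assay for permeability, using PAMPA, at pH 7.4; a lower number here means that the compound crosses the layer more slowly, a higher number that the compound crosses the layer faster. Compound 1 `Cc1cc(NC(=O)c2cc([N+](=O)[O-])ccc2Cl)cc(-c2nc3ccccc3s2)c1O` gives 48 10^-6 cm/s. For compound 2 `O=C(Nc1cc(-c2nc3ccccc3s2)ccc1Cl)c1cc([N+](=O)[O-])ccc1Cl` the result is "below limit of detection" (no number reported). Compound 3 `O=C(Nc1nc(-c2ccc(Cl)cc2)cs1)c1cc([N+](=O)[O-])ccc1Cl` gives 3 10^-6 cm/s, the lowest of the two numbers reported; compound 1 sits well above it, and that gap lies beyond the usual scatter. Compound 4 `O=C(Nc1nc(-c2ccc(F)c(F)c2)cs1)c1cc([N+](=O)[O-])ccc1Cl` has not yet been measured. It differs from compound 3 in one place: 3,4-difluorophenyl in place of 4-chlorophenyl on an aromatic carbon. Within the data shown here, no measured pair isolates this change, so the expected step of no change at the digits printed from compound 3 to compound 4 (within the scatter) is taken to be small, with no clear direction beyond the scatter. Compound 4 is estimated to give 3 10^-6 cm/s, within a range from 1 10^-6 cm/s to 8 10^-6 cm/s.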

Compound 4, apparent permeability: 37 10^-6 cm/s
The estimate for compound 4 lay 12-fold (1.09 log units) below the measured number; measured number outside the range, above it.
By their numbers in this assay, from the lowest: compound 3; then compounds 4 and 1 (each within the scatter of the next).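

Among these compounds, compound 3 and compound 4 form the first measured pair that differs in only one place, so this position can now be read directly. On the five-membered aromatic ring, next to the ring nitrogen, 3,4-difluorophenyl in place of 4-chlorophenyl gives a 12-fold higher number from compound 3 to compound 4 (1.09 log units; beyond the scatter) in this assay and so shows that this change can matter greatly. Nothing measured here explains the step. The pair cannot separate losing the chlorine from adding either fluorine, since these changes occur together. As far as these compounds go, how a plain phenyl ring or a phenyl ring carrying an amine would behave at this position remains open.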